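Adding One Fluoro to Compound 2

A few compounds are considered here, and "the series" means these few. Any claim that something is new, unique, unknown or untested is made for them only; others in the source may bear on it.

Compound 1 `CC1=C(/C=C/C2=NN(c3ccc(F)cc3)C(c3ccc(-n4cncn4)cc3)C2)C(C)(C)CCC1`: 58600 nM
Compound 2 `CC1=CCCC(C)(C)C1/C=C/C1=NN(c2ccccc2)C(c2ccc(-n3cncn3)cc2)C1`: 296000 nM

In an ADME assay on Vero cells (Chlorocebus sabaeus) for cytotoxicity, read by MTT assay, with a stated time of 72 h (a higher number here means that more compound is tolerated, a lower number that less compound is tolerated), compound 2 stands at 296000 nM and holds the higher of the two numbers, beyond the scatter from compound 1. Compound 3 `CC1=CCCC(C)(C)C1/C=C/C1=NN(c2ccc(F)cc2)C(c2ccc(-n3cncn3)cc2)C1` swaps phenyl for 4-fluorophenyl on compound 2, a change counted as fluoro in place of hydrogen on an aromatic carbon and placed on an aromatic carbon, para to a large group. Among the compounds with values here, compound 1 also carries 4-fluorophenyl and gives 58600 nM here, but no measured pair isolates this change. In this assay a modest fall beyond the scatter is expected, with a 2.5-fold lower number from compound 2 to compound 3 (0.39 log units; beyond the scatter) as the estimate. For compound 3 the estimated value is 120000 nM (expected range 50000 nM to 280000 nM).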

Compound 3, half-maximal cytotoxic concentration: 72200 nM
Compound 3: the middle estimate sits 1.7-fold (0.22 log units) above what was measured; the range from low to high includes it.
By their numbers in this assay, from the lowest: compounds 1 and 3 (each within the scatter of the next); then compound 2.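

Fluoro in place of hydrogen on an aromatic carbon gives a 4.1-fold lower number from compound 2 to compound 3 (0.61 log units; beyond the scatter) in this assay, so this single atom clearly changes the tolerated concentration. With the 4-fluorophenyl in place, 2,6,6-trimethylcyclohex-2-en-1-yl in place of 2,6,6-trimethylcyclohex-1-en-1-yl gives only a 1.2-fold higher number from compound 1 to compound 3 (0.09 log units; within the scatter), so this swap shows no real change. Nothing here explains why the fluoro step has this effect. Still open, going by these compounds, is how chloro, methoxy or an amine on the same aromatic carbon would compare with fluoro.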